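A few compounds are considered here, and "the series" means these few. Any claim that something is new, unique, unknown or untested is made for them only; others in the source may bear on it.

Of the compounds shown here, three of one family have been tested in a functional assay on CHO cells with adenosine receptor A1 (Homo sapiens) as the target, read by cAMP accumulation and immunoassay, with a stated time of 6 min, tested at 0.1 uM (a higher number here means a weaker effect of the compound at the concentration tested, a lower number a stronger effect), and all three give numbers close to zero. Compound 1, `COc1ccc(N2CCN(Cc3csc(N)c3C(=O)c3ccc(Cl)cc3)CC2)cc1`, gives 0%. Compound 2, `Nc1scc(CN2CCC(c3ccc(Cl)cc3)CC2)c1C(=O)c1ccc(Cl)cc1`, gives -2.3%, and compound 3, `Nc1scc(CN2CCN(c3c(F)cccc3F)CC2)c1C(=O)c1cccc(C(F)(F)F)c1`, gives 1.3%. Compound 1 thus stands second highest of the three numbers, but its nearest neighbour, compound 3, and its furthest, compound 2, both lie within the usual scatter of it, so the three values cannot be told apart.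

Compound 4, `Nc1scc(CN2CCN(C3CCCCCC3)CC2)c1C(=O)c1ccc(Cl)cc1`, has not yet been measured. It differs from compound 1 in one place: cycloheptyl in place of 4-methoxyphenyl on an amine nitrogen in a ring. Among the measured compounds shown here, no pair of measured compounds changes in just one place, so the size of this kind of step is not known from the data. Since the three measured compounds, with quite different groups around the shared core, all sit near zero in this assay, no step beyond the scatter is expected for compound 4. Compound 4 is therefore expected to give about 1%, within a range of -9% to 11%, which would mean an estimated step of a number 1 percentage points higher from compound 1 to compound 4 (within the scatter).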

Compound 4, a percentage reported as activity, at one concentration (the size of the read-out at that concentration, not a potency): 13%
The estimate for compound 4 lay 12 percentage points below the measured number; the whole stated range lies below it.
By their numbers in this assay, from the lowest: compounds 2, 1 and 3 (each within the scatter of the next); then compound 4.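

Cycloheptyl in place of 4-methoxyphenyl on the amine nitrogen in the ring gives, in this assay, a number 13 percentage points higher from compound 1 to compound 4 (beyond the scatter), the first step in one place that can be read in this family. The group at this position can therefore shift the read-out, even though the size of the shift is modest, and the higher number here means a weaker effect at the concentration tested. No measurement at hand explains this step.

The change replaces a six-membered aromatic ring with a seven-membered non-aromatic ring and also removes the oxygen, so these features cannot be separated from this one pair. Plain phenyl would test the role of the methoxy group, while cyclohexyl would test ring size, and what either would give remains open.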